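The source may hold more compounds than are shown below. What is called first, only, known or untested is meant among the compounds shown, and "the series" means these compounds.

Compound 3 `C=CCn1c(=O)/c(=C\c2ccc(F)c(Br)c2)[nH]c(=O)/c1=C\c1ccccc1OC` carries an allyl group and a 3-bromo-4-fluorophenyl arm on the shared core, and in a functional assay on NCI-H1975 cells (Homo sapiens) for cytotoxicity, read by CCK-8 assay, with a stated time of 72 h (a higher number here means a weaker inhibitor, a lower number a stronger inhibitor), compound 3 gives "not active" (no number reported). Compound 1 `COc1ccccc1/C=c1/[nH]c(=O)/c(=C\c2ccccc2OC)[nH]c1=O` also gives "not active" (no number reported) in this assay, while compound 2 `C=CCn1c(=O)/c(=C\c2cccc(F)c2)[nH]c(=O)/c1=C\c1ccccc1OC` reaches only 25600 nM, a weak result. Compound 4 `C=CCn1c(=O)/c(=C\c2ccccc2OC)[nH]c(=O)/c1=C\c1ccccc1OC` differs from compound 3 by 2-methoxyphenyl in place of 3-bromo-4-fluorophenyl on a double-bonded chain carbon bound to an aromatic carbon; this makes compound 4 the allyl counterpart of compound 1. With two neighbours showing no activity and the third barely active, the step from compound 3 to compound 4 in this assay is expected to bring no gain, and compound 4 is expected to sit near the edge of detection, around 40000 nM, between 15000 nM and 100000 nM.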

Compound 4, half-maximal inhibitory concentration: 21500 nM
Compound 4: middle estimate off by 1.9-fold (0.27 log units), on the high side; the measured number falls inside the stated range.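

In this assay compound 4 gives 21500 nM and compound 3 gives "not active" (no number reported), so a 2-methoxyphenyl arm at this place keeps weak but measurable activity, although no size can be read for this step. Replacing 3-fluorophenyl with 2-methoxyphenyl gives a 1.2-fold lower number from compound 2 to compound 4 (0.08 log units; within the scatter), so these two arms cannot be told apart here. No measurement available here explains how the arms compare. From the compounds shown here alone, whether an arm carrying an amine or a carboxylic acid would give a much lower number remains open.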